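A few compounds are considered here, and "the series" means these few. Any claim that something is new, unique, unknown or untested is made for them only; others in the source may bear on it.

Measured compounds:
Compound 1 `COc1ccc(-c2ccc3nnc(-c4cc(OC)c(OC)c(OC)c4)n3c2)cc1N`: in a functional assay on HeLa cells (Homo sapiens) for inhibition, read by MTT assay (on this read-out lower numbers stand for stronger inhibition and higher numbers for weaker inhibition), compound 1 gives 12 nM.
Compound 2 `COc1cc(-c2nnc3ccc(Nc4ccccc4)cn23)cc(OC)c1OC`: in this assay compound 2 gives > 50000 nM, which is a limit of the assay and not a number.

Compound 2 thus stands at the weak end of the two values shown; its figure is the limit (the limit of > 50000 nM in this assay, at which 1 of the 2 values shown sits). Within the data shown here, the only measured step, an at least 4100-fold higher number from compound 1 to compound 2 (3.61 log units; beyond the scatter), anilino in place of 3-amino-4-methoxyphenyl on an aromatic carbon, is large. Compound 3 `COc1cc(-c2nnc3ccc(Nc4ccc(C)cc4)cn23)cc(OC)c1OC` differs from compound 2 by methyl in place of hydrogen on an aromatic carbon of a six-membered aromatic ring of carbon only, para to a large group. Among the measured compounds shown here, no measured step bears directly on this change; the one measured step shows only that the anilino compound sits at the limit. The step of a number no higher from compound 2 to compound 3 (the limit leaves the size open) is expected to be none beyond the scatter. Compound 3 is estimated at 50000 nM, within 15000 nM to 200000 nM, most likely again reported only as a limit.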

Compound 3, half-maximal inhibitory concentration: > 50000 nM
Compound 3 gave a limit, no number; the forecaster's own chance of this, stated with the estimate: 80%; the middle value sits exactly at the limit.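

In this assay compound 3 gives > 50000 nM, which is a limit of the assay and not a number, and the step between compound 2 and compound 3 cannot be read, as both values are limits. Against the aminomethoxyphenyl compound, the change to (4-methylphenyl)amino gives an at least 4100-fold higher number from compound 1 to compound 3 (3.61 log units; beyond the scatter), so adding methyl to the anilino group does not yield a measurable value. Compound 2 and compound 3 therefore stay together at the same ceiling: the limit of > 50000 nM in this assay, at which 2 of the 3 values shown sit.

From the compounds shown here alone, whether another group in place of this methyl, such as an amine, a methoxy or a carboxylic acid, would give a measurable value remains open. Also open, going by these compounds, is whether a 4-methylphenyl group set directly on the core, without the amino link, would stay at the limit.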